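The source may report more compounds than this note shows. Statements on the series, on what has been measured and on what is new or still open speak of the compounds shown alone.

Compound 1: `Cc1ccc(N2CCN(C(=O)[C@H](C)Cc3ccc(Cl)cc3F)CC2)c([C@@H](N)CC(C)C)c1`, 20 nM
Compound 2: `CC(C)C[C@H](N)c1cc(C(F)(F)F)ccc1N1CCN(C(=O)CC(C)C(=O)c2ccc(Cl)cc2)CC1`, 1100 nM

In an assay on HEK293 cells for displacement of a labelled ligand from Melanocortin receptor 4 (Homo sapiens) (a lower number here means a stronger inhibitor, a higher number a weaker inhibitor), compound 1 gives 20 nM. Compound 2 gives 1100 nM in this assay, the higher of the two numbers, and its gap to compound 1 lies beyond the scatter. Compound 3, `CCOc1cccc(CC(C)C(=O)N2CCN(c3ccc(C(F)(F)F)cc3[C@@H](N)CC(C)C)CC2)c1`, has not yet been measured; it differs from compound 2 in one place: 1-(3-ethoxybenzyl)ethyl in place of 2-((4-chlorophenyl)carbonyl)propyl on a carbonyl carbon. Because compound 1, which also carries a 1-benzyl-ethyl type group on that carbonyl carbon, gives 20 nM, the step from compound 2 to compound 3 is expected to be a clear drop in the number, an 11-fold lower number from compound 2 to compound 3 (1.04 log units; beyond the scatter). Compound 3 is estimated at 100 nM, with a range from 25 nM to 400 nM.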

Compound 3, inhibition constant: 2200 nM
For compound 3 the middle estimate is 22-fold (1.34 log units) below the measured one; the measured number lies above the stated range.
By their numbers in this assay, from the lowest: compound 1; then compounds 2 and 3 (each within the scatter of the next).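

In this assay, putting 1-(3-ethoxybenzyl)ethyl in place of 2-((4-chlorophenyl)carbonyl)propyl on the carbonyl carbon gives a 2.0-fold higher number from compound 2 to compound 3 (0.30 log units; within the scatter), so these two groups cannot be told apart at this position. A 1-benzyl-ethyl type group on this carbonyl carbon therefore does not by itself secure a low number on the core shared by these two compounds. No measurement at hand explains this result. Going by these compounds, it remains open whether 1-(3-ethoxybenzyl)ethyl would behave differently on the core of compound 1, and whether an amine or a carboxylic acid on the benzyl ring would shift the number.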